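Five-membered ring swaps on a shared core

The compounds below may be only part of what the source reports. "The series", "measured", "known", "first", "only" and "open" are said of these compounds alone.

Measured so far in a functional assay on CHO cells for antagonist activity at prostaglandin E2 receptor EP3 subtype (Homo sapiens), read by cAMP accumulation; on this read-out lower numbers stand for stronger inhibition and higher numbers for weaker inhibition:
compound 1 `CC(C)C(Cc1nnc[nH]1)c1ccc(-c2ccc3cccc(F)c3c2)[nH]c1=O` gives 17 nM
compound 2 `CC(C)C(c1noc(=O)[nH]1)c1ccc(-c2ccc3cccc(F)c3c2)[nH]c1=O` gives 41 nM
compound 3 `CC(C)C(c1ccc(-c2ccc3cccc(F)c3c2)[nH]c1=O)N1CCNC1=O` gives 28 nM

Compound 3 stands second highest of the three numbers. Its nearest neighbour is compound 2, with a 1.5-fold lower number from compound 2 to compound 3 (0.17 log units; within the scatter); the furthest is compound 1, with a 1.6-fold higher number from compound 1 to compound 3 (0.22 log units; within the scatter). Both of these steps sit inside the scatter, so compound 3 cannot be ordered against either of the other two.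

Compound 4 `CC(C)C(/C=C1\CCNC1=O)c1ccc(-c2ccc3cccc(F)c3c2)[nH]c1=O` differs from compound 3 in one place: a group of 7 heavy atoms (5 carbon, 1 nitrogen, 1 oxygen; one five-membered non-aromatic ring with 1 hetero atom) in place of a group of 6 heavy atoms (3 carbon, 2 nitrogen, 1 oxygen; one five-membered non-aromatic ring with 2 hetero atoms), on a saturated chain carbon bound to an aromatic carbon and a saturated chain carbon.

For the measured compounds named here, the steps that bear on this change are the earlier ring swaps on the saturated chain carbon bound to an aromatic carbon and a saturated chain carbon: a 1.6-fold higher number from compound 1 to compound 3 (0.22 log units; within the scatter) and a 1.5-fold lower number from compound 2 to compound 3 (0.17 log units; within the scatter), both within the scatter, and the modest 2.4-fold higher number from compound 1 to compound 2 (0.38 log units; beyond the scatter). Going by the values given here, three different five-membered rings there gave numbers in a narrow band, so a fourth ring is expected to move the number only a little; the new ring, with its second double bond outside aromatic rings, has no counterpart among the measured compounds, which keeps the range wide. A step of a 1.3-fold higher number from compound 3 to compound 4 (0.10 log units; within the scatter) is expected, with no direction beyond the scatter. For compound 4 the estimate in this assay is 35 nM, between 12 nM and 100 nM.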

Compound 4, half-maximal inhibitory concentration: 8.7 nM
Beside the measured number, compound 4's estimate is 4.0-fold (0.60 log units) above it, outside the stated range (below it).
By their numbers in this assay, from the lowest: compounds 4, 1, 3 and 2 (each within the scatter of the next, the first and the last beyond it).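

For the compounds shown here, at the saturated chain carbon bound to an aromatic carbon and a saturated chain carbon, the earlier ring swaps gave only one step beyond the scatter, whereas in this assay the new group gives two: a 3.2-fold lower number from compound 3 to compound 4 (0.51 log units; beyond the scatter) and a 4.7-fold lower number from compound 2 to compound 4 (0.67 log units; beyond the scatter). Going by these compounds alone, the number at this position therefore responds to the choice of five-membered ring more than the earlier compounds showed, although the step against the triazole-bearing compound, a 2.0-fold lower number from compound 1 to compound 4 (0.29 log units; within the scatter), stays within the scatter and so sets no order between those two compounds. Nothing measured here accounts for these steps.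

The step from compound 3 to compound 4 changes the heavy atom count, the ring hetero atom count and the count of double bonds outside aromatic rings together, so the compounds shown do not tell which of these changes goes with the lower number. Also open, as far as these compounds go, is whether a primary amine or a carboxylic acid on this same carbon, or a version of the entering ring with its outside double bond reduced to a single bond, would stay in this range.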